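Swapping a methoxybenzyl arm for a dioxolane ring

This account rests on a few compounds, and the source may have more. Where it says the series, first, only, none or still open, it means among the compounds named here.

Compound 1, `COc1cccc(Cn2cc(-c3ccc(C(F)(F)F)cc3)nn2)c1`: 17400 nM in a functional assay on B16 cells (Mus musculus) for cytotoxicity, read by MTT assay, with a stated time of 48 h; a lower number here means a stronger inhibitor, a higher number a weaker inhibitor
Compound 2, `CC1(C)OC[C@H](Cn2cc(-c3ccc([N+](=O)[O-])cc3)nn2)O1`: > 100000 nM in this assay, a limit of the assay rather than a number

For the measured compounds named here, only two compounds have been measured, and only one of them yields a number. Going by the values given here, compound 1, with a trifluoromethyl-bearing aromatic ring on one side of the shared core and a 3-methoxyphenyl group on the chain carbon attached to the core nitrogen, gives 17400 nM; that is the sole numeric reading available. Compound 2 carries a nitro-bearing aromatic ring instead and a 2,2-dimethyl-1,3-dioxolan-4-yl group on that chain carbon, and it reaches only a limit of this assay, > 100000 nM.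

The unmeasured compound 3, `CC1(C)OCC(Cn2cc(-c3ccc(C(F)(F)F)cc3)nn2)O1`, keeps the trifluoromethyl-bearing ring of compound 1 and makes one change: 2,2-dimethyl-1,3-dioxolan-4-yl in place of 3-methoxyphenyl on a saturated chain carbon bound to an aromatic nitrogen. Among the compounds with values here, no directly comparable pair has been measured, so the size of this step is unknown. Compound 2, which carries the same dioxolane group, gives only a limit, > 100000 nM. On that basis the step from compound 1 to compound 3 is expected to weaken the compound, a 2.9-fold higher number from compound 1 to compound 3 (0.46 log units; beyond the scatter), beyond the usual scatter. For compound 3 a value around 50000 nM is estimated, most likely between 15000 nM and 150000 nM, with a real chance that only a limit is reported.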

Compound 3, half-maximal inhibitory concentration: 13500 nM
The estimate for compound 3 lay 3.7-fold (0.57 log units) above the measured number; measured number below the stated range.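

In this assay, the 2,2-dimethyl-1,3-dioxolan-4-yl group can stand in place of 3-methoxyphenyl on a saturated chain carbon bound to an aromatic nitrogen without a change that can be told from scatter: the step is a 1.3-fold lower number from compound 1 to compound 3 (0.11 log units; within the scatter). With the trifluoromethyl-bearing ring in the molecule, this position therefore accepts a five-membered non-aromatic ring with 2 hetero atoms as well as a six-membered aromatic ring of carbon only, so an aromatic ring on this chain carbon is not needed to keep a measurable number in this pair. The dioxolane group alone thus does not account for compound 2 giving a limit of the assay rather than a number: the limit of > 100000 nM in this assay, at which 1 of the 3 values shown sits.

Steps that involve compound 2 cannot be read, so the size of any effect of exchanging trifluoromethyl for nitro on the aromatic ring stays open. Also open, as far as these compounds go, is how this position would respond to a quite different group on the chain carbon, such as an amine, a carboxylic acid or a longer open chain.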